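Methoxy to fluoro on the triazole aryl: a cytotoxicity note

This account rests on a few compounds, and the source may have more. Where it says the series, first, only, none or still open, it means among the compounds named here.

Two members of this series have so far been run in a functional assay on MCF7 cells (Homo sapiens) for cytotoxicity, read by MTT assay, with a stated time of 4 days (a lower number here means a stronger inhibitor, a higher number a weaker inhibitor), and neither has returned a number. Compound 1 `C=C1C[C@]23C[C@@]1(O)CC[C@H]2c1ccc(OS(=O)(=O)c2ccc(C)cc2)c(C)c1[C@@H]3Cn1cc(-c2ccc(Br)cc2)nn1` gives > 20000 nM, which is a limit of the assay rather than a measured value. Compound 2 `C=C1C[C@]23C[C@@]1(O)CC[C@@H]2c1cccc(C)c1[C@@H]3Cn1cc(-c2ccc(OC)cc2)nn1` likewise gives > 20000 nM in this assay, again a limit and not a number. Among the measured compounds shown here, compound 2 therefore stands nowhere in particular on the scale: it sits at the limit of > 20000 nM in this assay, at which 2 of the 2 values shown sit, alongside the only other value in hand, and no step between measured compounds can be drawn from two limits.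

Compound 3 `C=C1C[C@]23C[C@@]1(O)CC[C@@H]2c1cccc(C)c1[C@@H]3Cn1cc(-c2ccc(F)cc2)nn1` is the next candidate. Its change from compound 2 is fluoro in place of methoxy on an aromatic carbon, a fluoro in place of methoxy on an aromatic carbon. Since both values shown are limits, nothing in the data points in either direction for this change. The expectation is that compound 3 also lands at or past the limit, with an estimated value of 30000 nM in this assay, within a range from 12000 nM to 80000 nM. The expected step that the limit leaves unreadable from compound 2 to compound 3 is none beyond the scatter.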

Compound 3, half-maximal inhibitory concentration: > 20000 nM
Compound 3: a limit, no number; the forecaster's own chance of this, stated with the estimate: 75%; the middle value does not contradict the limit.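

In this assay compound 3 gives > 20000 nM, a limit and not a number. Compound 2 also stands at a limit, so fluoro in place of methoxy gives no readable step between compound 2 and compound 3: the limit of > 20000 nM in this assay, at which 3 of the 3 values shown sit.

The compounds shown leave open how far each lies past that limit, and whether any change on the shared core gives a measurable value.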